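The source may hold more compounds than are shown below. What is called first, only, known or untested is meant among the compounds shown, and "the series" means these compounds.

Working notes on the series. Compound 1 `CCSC[C@@](O)([C@@H](Nc1cccc2nc(C)ccc12)c1ccc(OC)cc1)C(F)(F)F` in a functional assay on THP-1 cells (Homo sapiens) (a higher number here means a larger maximal response, a lower number a smaller maximal response), gives 86%. Going by the values given here, compound 2 `CCSC[C@@](O)([C@@H](Nc1cccc2nc(C)ccc12)c1ccc(F)cc1OC)C(F)(F)F` in this assay gives 78% and stands at the lower end of the two numbers so far, with compound 1 nearest and within the scatter. Among the compounds with values here, the one measured step is a number 8 percentage points lower from compound 1 to compound 2 (within the scatter). Compound 3 `CCSC[C@@](O)([C@@H](Nc1cccc2nc(C)ccc12)c1ccc(OC)cc1F)C(F)(F)F` has not yet been measured in this assay. It differs from compound 2 in one place: 2-fluoro-4-methoxyphenyl in place of 4-fluoro-2-methoxyphenyl on a saturated chain carbon bound to a nitrogen on an aromatic ring and a saturated chain carbon. Within the data shown here, the only step that bears on this, a rearrangement of the same two substituents on the phenyl, is a number 8 percentage points lower from compound 1 to compound 2 (within the scatter), which stayed within the scatter. No shift beyond the scatter is therefore expected for this further rearrangement, and the direction cannot be read from two numbers. The expected step is a number 4 percentage points higher from compound 2 to compound 3 (within the scatter). For compound 3 in this assay the estimate is 82%, within a range from 70% to 94%.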

Compound 3, largest response reached (Emax), in percent of the reference or control that the assay uses: 85%
The estimate for compound 3 lay 3 percentage points below the measured number; the measured number falls inside the stated range.
By their numbers in this assay, from the lowest: compounds 2, 3 and 1 (each within the scatter of the next).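

In this assay, 2-fluoro-4-methoxyphenyl in place of 4-fluoro-2-methoxyphenyl gives a number 7 percentage points higher from compound 2 to compound 3 (within the scatter) and so shows that exchanging the two substituents on this phenyl does not separate the two compounds. Compound 3 also isolates a single addition that the earlier pair could not show: fluoro in place of hydrogen on an aromatic carbon gives a number 1 percentage points lower from compound 1 to compound 3 (within the scatter) and leaves the maximal response of the 4-methoxyphenyl compound within the scatter. No available evidence explains this tolerance. Still open, from the compounds shown here alone, is whether an amine or a carboxylic acid on this phenyl would move the maximal response beyond the scatter. Also open, going by these compounds, is whether a longer chain in place of the ethyl on sulfur would do so.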